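From triazolyl to pyrazolyl on one carbonyl

The compounds below may be only part of what the source reports. "The series", "measured", "known", "first", "only" and "open" are said of these compounds alone.

In an ADME assay on microsomes (Rattus norvegicus) for metabolic stability (on this read-out higher numbers stand for a longer-lived compound and lower numbers for a shorter-lived compound), compound 1 `CCC(=O)N1CCC(C(=O)N2N=CCC2c2ccccc2)CC1` gives 1.07 h and compound 2 `O=C(C1CCN(C(=O)C(F)(F)F)CC1)N1N=CCC1c1ccccc1` gives 0.483 h. Compound 3 `O=C(c1c[nH]nn1)N1CCC(C(=O)N2N=CCC2c2ccccc2)CC1` gives > 2.75 h, which is a limit and not a number. Compound 4 `O=C(c1cc[nH]n1)N1CCC(C(=O)N2N=CCC2c2ccccc2)CC1` differs from it on a carbonyl carbon: 1H-pyrazol-3-yl in place of 1H-1,2,3-triazol-4-yl on a carbonyl carbon. Two measured steps change this same place, an at least 2.5-fold higher number from compound 1 to compound 3 (0.40 log units; beyond the scatter) and an at least 5.6-fold higher number from compound 2 to compound 3 (0.75 log units; beyond the scatter), while neither tests 1H-pyrazol-3-yl directly. Compound 4 keeps a five-membered aromatic ring there, so most of the gain in an at least 2.5-fold higher number from compound 1 to compound 3 (0.40 log units; beyond the scatter) should remain. The expected step is an at least 1.1-fold lower number from compound 3 to compound 4 (0.05 log units; that floor lies within the scatter), and no change beyond the scatter is expected in this assay. The estimate for compound 4 is 2.4 h, with an expected range of 1.2 h to 4.8 h.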

Compound 4, half-life: 0.317 h
For compound 4 the middle estimate is 7.6-fold (0.88 log units) above the measured one; measured number below the stated range.
By their numbers in this assay, from the lowest: compounds 4 and 2 (each within the scatter of the next); then compound 1. At a limit, above all of these: compound 3.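

Keeping a five-membered aromatic ring on this carbonyl does not by itself hold the number in this assay: 1H-pyrazol-3-yl in place of 1H-1,2,3-triazol-4-yl gives an at least 8.6-fold lower number from compound 3 to compound 4 (0.93 log units; beyond the scatter). The figure for compound 3 is a limit and not a number: the limit of > 2.75 h in this assay, at which 1 of the 4 values shown sits. Against the ethyl group, 1H-pyrazol-3-yl gives a 3.4-fold lower number from compound 1 to compound 4 (0.53 log units; beyond the scatter), and against trifluoromethyl it gives a 1.5-fold lower number from compound 2 to compound 4 (0.18 log units; within the scatter), so none of the gain seen with the triazolyl group survives.

Still open, going by these compounds, is how far the true value of compound 3 lies from its limit. Also open, on these data alone, is whether the gain belongs to the triazolyl group alone, which a tetrazolyl or imidazolyl group on this carbonyl would test.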